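This account rests on a few compounds, and the source may have more. Where it says the series, first, only, none or still open, it means among the compounds named here.

For the measured compounds named here, compound 2 `COc1cc2c(Oc3ccc(NC(=O)NN4C(=O)CSC4c4cccc(F)c4F)cc3)ccnc2cc1OC1CCN(C(=O)NC(C)C)CC1` gives 790 nM in a functional assay on HT-29 cells (Homo sapiens) for inhibition, read by MTT assay (a higher number here means a weaker inhibitor, a lower number a stronger inhibitor), the lowest of the two numbers so far; compound 1 `COc1cc2c(Oc3ccc(NC(=O)NN4C(=O)CSC4c4ccc(F)cc4)cc3)ccnc2cc1OC1CCN(C(=O)NC(C)C)CC1` gives 860 nM in this assay, and the step of a 1.1-fold lower number from compound 1 to compound 2 (0.04 log units; within the scatter) sits within the scatter. Compound 3 `COc1cc2c(Oc3ccc(NC(=O)NN4C(=O)CSC4c4cccc(F)c4)cc3)ccnc2cc1OC1CCN(C(=O)NC(C)C)CC1` carries hydrogen in place of fluoro on an aromatic carbon. Going by the values given here, only one measured step bears on this, and loosely: it altered the fluoro pattern on the same phenyl and gave a 1.1-fold lower number from compound 1 to compound 2 (0.04 log units; within the scatter). Dropping a single fluoro is therefore expected to move this assay by no more than the scatter, with no preferred direction. Compound 3 is expected at 820 nM in this assay, between 400 nM and 1700 nM, a step of a 1.0-fold higher number from compound 2 to compound 3 (0.02 log units; within the scatter).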

Compound 3, half-maximal inhibitory concentration: 670 nM
Estimate against measurement, compound 3: 1.2-fold (0.09 log units) above; the measured number falls inside the stated range.
By their numbers in this assay, from the lowest: compounds 3, 2 and 1 (each within the scatter of the next).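

In this assay, going from 2,3-difluorophenyl to 3-fluorophenyl gives a 1.2-fold lower number from compound 2 to compound 3 (0.07 log units; within the scatter), so this fluoro can be removed without leaving the scatter. Changing 4-fluorophenyl to 3-fluorophenyl gives a 1.3-fold lower number from compound 1 to compound 3 (0.11 log units; within the scatter), also within the scatter. Across these three compounds, neither the number of fluoro groups nor their place on this phenyl separates the values, and no supporting data bear on why.

On these data alone, whether the phenyl without any fluoro reads the same remains open. So does the effect of a different group here, such as methoxy, an amine or a carboxylic acid.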